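One Carbonyl Substituent Swap Without a Measured Precedent

The compounds below may be only part of what the source reports. "The series", "measured", "known", "first", "only" and "open" are said of these compounds alone.

Compound 1 `O=C(Nc1cccc(-n2cc(-c3ccncc3)c(-c3cc(O)cc(Cl)c3)n2)c1)Nc1ccc(Cl)c(Cl)c1`: 93%
Compound 2 `COc1cc(Cl)cc(-c2nn(-c3cccc(NC(=O)Nc4ccc(Cl)c(Cl)c4)c3)cc2-c2ccncc2)c1`: 92%

In a functional assay on U-251 cells (Homo sapiens) for inhibition, read by sulforhodamine B assay, with a stated time of 48 h, tested at 0.1 uM (on this read-out lower numbers stand for a stronger effect and higher numbers for a weaker effect at the one concentration tested), compound 1 gives 93% and compound 2 gives 92%. Among the measured compounds shown here, the only measured step, a number 1 percentage points lower from compound 1 to compound 2 (within the scatter), lies within the scatter, so compound 2 stands level with compound 1 rather than apart from it. Compound 3 `COc1cc(Cl)cc(-c2nn(-c3cccc(NC(=O)c4cccc(C(F)(F)F)c4)c3)cc2-c2ccncc2)c1` differs from compound 2 by 3-(trifluoromethyl)phenyl in place of (3,4-dichlorophenyl)amino on a carbonyl carbon. That step, methyl in place of hydrogen on an oxygen, touches a different part of the molecule and says nothing about this exchange at the carbonyl carbon. For the measured compounds named here, with no bearing precedent, no shift beyond the scatter is assumed. Compound 3 is therefore expected at 90%, between 70% and 102%. The expected change is a number 2 percentage points lower from compound 2 to compound 3 (within the scatter).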

Compound 3, a percentage reported as activity, at one concentration (the size of the read-out at that concentration, not a potency): 91%
Compound 3: middle estimate off by 1 percentage points, on the low side; the measured number falls inside the stated range.
By their numbers in this assay, from the lowest: compounds 3, 2 and 1 (each within the scatter of the next).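

Putting 3-(trifluoromethyl)phenyl in place of (3,4-dichlorophenyl)amino on the carbonyl carbon gives a number 1 percentage points lower from compound 2 to compound 3 (within the scatter) in this assay at the one concentration tested. This shows that a change at the carbonyl carbon, not only the earlier one on the oxygen, can leave the read-out level, even though the hydrogen-bond donor of the leaving group is gone. No measurement at hand gives a reason for this. As far as these compounds go, whether a morpholine or a cyclohexyl group on that carbonyl carbon would move the number beyond the usual scatter stays open. So does the behaviour of compound 3 at any other concentration.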